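A few compounds are considered here, and "the series" means these few. Any claim that something is new, unique, unknown or untested is made for them only; others in the source may bear on it.

Compound 1, `C=CCn1c(=O)/c(=C\c2cc(F)ccc2C)[nH]c(=O)/c1=C\c1ccccc1OC`, is the starting point of this account. In a functional assay on A549 cells (Homo sapiens) for cytotoxicity, read by CCK-8 assay, with a stated time of 72 h (on this read-out lower numbers stand for stronger inhibition and higher numbers for weaker inhibition), compound 1 gives 4900 nM, the highest of the two numbers recorded in the set. Its nearest neighbour is compound 3, `COc1ccccc1/C=c1/[nH]c(=O)/c(=C\c2nc[nH]c2C(C)(C)C)[nH]c1=O`, which in this assay gives 90 nM, a far lower number than compound 1 and a gap that lies beyond the usual scatter. Compound 2, `C=CCn1c(=O)/c(=C\c2cccc(Br)c2)[nH]c(=O)/c1=C\c1cccc(Br)c1`, is reported in this assay as "not active" (no number reported), without a number attached.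

The step under consideration leads from compound 1 to compound 4, `C=CCn1c(=O)/c(=C\c2ccccc2Cl)[nH]c(=O)/c1=C\c1ccccc1OC`. The change is 2-chlorophenyl in place of 5-fluoro-2-methylphenyl on a double-bonded chain carbon bound to an aromatic carbon. The rest of the shared core, including the allyl group and the 2-methoxyphenyl side, is unchanged. Within the data shown here, no measured pair in the set isolates this particular exchange, so the size of the step rests on judgement alone. Compound 4 is expected to give 3500 nM in this assay, within a range of 1200 nM to 10000 nM. That estimate means a step of a 1.4-fold lower number from compound 1 to compound 4 (0.15 log units; within the scatter), expected to stay within the scatter or to be at most a small move toward a lower number.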

Compound 4, half-maximal inhibitory concentration: 5300 nM
The estimate for compound 4 lay 1.5-fold (0.18 log units) below the measured number, within the range that was stated.
By their numbers in this assay, from the lowest: compound 3; then compounds 1 and 4 (each within the scatter of the next).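

In this assay, among these compounds, the exchange of 5-fluoro-2-methylphenyl for 2-chlorophenyl on a double-bonded chain carbon bound to an aromatic carbon amounts to a 1.1-fold higher number from compound 1 to compound 4 (0.03 log units; within the scatter), the only step in the set that isolates a single place. With the allyl group and the 2-methoxyphenyl side unchanged, the number does not separate these two aryl groups, so this particular exchange leaves the read-out where it was. Nothing at hand offers an explanation for this result.

The compounds shown leave open whether any other group at this place would move the number, for instance a phenyl ring carrying an amine or a carboxylic acid. They also leave open whether the same exchange would behave alike with a longer chain in place of the allyl group.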